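A few compounds are considered here, and "the series" means these few. Any claim that something is new, unique, unknown or untested is made for them only; others in the source may bear on it.

Measured compounds:
- Compound 1, `COc1ccc(/C=C\C(=O)O)c(OCc2cn(-c3ccc(NC(C)=O)cc3)nn2)c1CC=C(C)C`: "not determined" (no result reported) in a functional assay on A549 cells (Homo sapiens) for cytotoxicity, read by MTT assay, with a stated time of 24 h; on this read-out lower numbers stand for stronger inhibition and higher numbers for weaker inhibition
- Compound 2, `COc1ccc(/C=C\C(=O)O)c(OCc2cn(-c3cccnc3Cl)nn2)c1CC=C(C)C`: 5600 nM in this assay

Compound 1 carries no number in this assay, so compound 2 stands alone among the values shown; in this assay compound 2 gives 5600 nM, and there is no second number against which that value could be ranked.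

Compound 3, `COc1ccc(/C=C\C(=O)O)c(OCc2cn(-c3ccccc3C#N)nn2)c1CC=C(C)C`, keeps the whole of the shared core and differs from compound 2 in one place only: 2-cyanophenyl in place of 2-chloropyridin-3-yl on an aromatic nitrogen. No step between two measured compounds is shown for this change or for any other, so the expectation rests on the single value of compound 2 and on the small size of the exchange. The step from compound 2 to compound 3 is expected to stay within the usual scatter, with no clear direction, a 1.1-fold higher number from compound 2 to compound 3 (0.03 log units; within the scatter). On that basis compound 3 is estimated at 6000 nM in this assay, with a range from 2500 nM to 15000 nM.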

Compound 3, half-maximal inhibitory concentration: 38600 nM
The estimate for compound 3 lay 6.4-fold (0.81 log units) below the measured number, outside the stated range (above it).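

The group on the aromatic nitrogen of the five-membered aromatic ring with 3 nitrogen matters in this assay: with the shared core unchanged, 2-cyanophenyl in place of 2-chloropyridin-3-yl gives a 6.9-fold higher number from compound 2 to compound 3 (0.84 log units; beyond the scatter), a modest step toward weaker inhibition. The exchange therefore does not behave as a neutral swap of one six-membered aromatic ring for another, even though the two groups have the same counts of hydrogen-bond donors and acceptors and neither carries a net charge. No measurement on hand bears on the reason for this step.

The exchange alters the ring hetero atom and the group on the ring together, so this single step cannot show whether the loss of the ring nitrogen, the loss of chlorine or the arrival of the nitrile accounts for the difference. As far as these compounds go, how a chlorophenyl group, a cyanopyridinyl group or an aminophenyl group would read at this position remains open, and compound 1, without a number, adds nothing to that comparison.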